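The compounds below may be only part of what the source reports. "The series", "measured", "known", "first", "only" and "open" are said of these compounds alone.

Compound 1 `O=C(NO)c1ccc(NCc2nc(-c3ccc(Br)o3)nn2-c2ccccc2)cc1`: 55.8%
Compound 2 `Cc1ccc(-n2nc(-c3ccccc3)nc2CNc2ccc(C(=O)NO)cc2)cc1`: 60.7%
Compound 3 `O=C(NO)c1ccc(NCc2nc(-c3ccc(Cl)c(Cl)c3)nn2-c2ccccc2)cc1`: 34.5%

Of the compounds shown here, three sharing one core have been measured in an assay on Sf9 cells for inhibition of protein deacetylase HDAC6 (Homo sapiens), read by fluorescence, with a stated time of 40 min, tested at 100 nM; a higher number here means more inhibition at the concentration tested (going by the name of the read-out), a lower number less inhibition. Compound 2 stands highest of the three numbers, but compound 1 lies within the scatter of it, so no order between those two can be claimed; compound 3 lies beyond the scatter below compound 2. Among the compounds with values here, the only step between compounds differing in one place is a number 21.3 percentage points lower from compound 1 to compound 3 (beyond the scatter), and it concerns the aryl group on the other side of the core, not the ring that carries the methyl in compound 2.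

Compound 4 `O=C(NO)c1ccc(NCc2nc(-c3ccccc3)nn2-c2ccccc2)cc1` differs from compound 2 by hydrogen in place of methyl on an aromatic carbon. Within the data shown here, no measured step touches this position, so there is nothing in these data to indicate a direction, and the loss of a single methyl is expected to leave the number where compound 2 sits. From compound 2 the expected step is a number 4.7 percentage points lower from compound 2 to compound 4 (within the scatter), within the scatter. Compound 4 is therefore estimated to give 56% in this assay, with a range from 40% to 70%.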

Compound 4, a percentage reported as inhibition, at one concentration (the size of the read-out at that concentration, not a potency): 72.6%
Compound 4: the middle estimate sits 16.6 percentage points below what was measured, and the stated range ends below it.
By their numbers in this assay, from the lowest: compound 3; then compounds 1 and 2 (each within the scatter of the next); then compound 4.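

In this assay, within the data shown here, the change from 4-methylphenyl to phenyl, on an aromatic carbon para to a large group, gives the first measured step at this position (a number 11.9 percentage points higher from compound 2 to compound 4 (beyond the scatter)), so hydrogen and methyl are not interchangeable here. Compound 4 also stands beyond the scatter of both compounds that differ from it in the other aryl group (a number 16.8 percentage points higher from compound 1 to compound 4 (beyond the scatter); a number 38.1 percentage points higher from compound 3 to compound 4 (beyond the scatter)), which makes it the highest of the four, and phenyl the highest-reading of the three aryl groups compared in that place. No measurement at hand bears on why these steps occur.

The compounds shown leave open whether any group at this position lowers the number or only methyl does, which a chlorine, a methoxy group or an amine in its place would show. They also leave open whether these differences would hold as differences in potency, since each number comes from a single concentration.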